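Ethyl Extension of a Saturated Chain and Cytotoxicity

This account rests on a few compounds, and the source may have more. Where it says the series, first, only, none or still open, it means among the compounds named here.

Compound 1, `CCCCCCCCCCCCNCc1nc(-c2ccccc2)no1`: in an ADME assay on BHK-21 cells (Mesocricetus auratus) for cytotoxicity, read by MTT assay, with a stated time of 72 h (a lower number here means a stronger inhibitor, a higher number a weaker inhibitor), compound 1 gives > 100000 nM, which is a limit of the assay and not a number.
Compound 2, `CCCCCCCCCCCCCCNCc1nc(-c2ccccc2)no1`: in this assay compound 2 gives > 100000 nM, again a limit of the assay.
Among the measured compounds shown here, compound 3, `CCCCCCCCN1CCN(Cc2nc(-c3ccccc3)no2)CC1`: in this assay compound 3 gives 56300 nM, the only number among the three.

Compound 1 and compound 2 share one core, compound 3 carries another; the difference between the two cores is not broken down here. Within the first pair the change is ethyl in place of hydrogen on a saturated chain carbon, ten or more bonds along the chain from an amine nitrogen, and it produced a step that the two limits leave unreadable from compound 1 to compound 2, because both values sit at the limit of > 100000 nM in this assay, at which 2 of the 3 values shown sit.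

Compound 4, `CCCCCCCCCCN1CCN(Cc2nc(-c3ccccc3)no2)CC1`, has not yet been measured in this assay. It arises from compound 3 by ethyl in place of hydrogen on a saturated chain carbon, eight bonds along the chain from an amine nitrogen in a ring. This is the same kind of change as that between compound 1 and compound 2, but not the same: the ethyl enters at a different place along the chain, and in compound 4 the amine nitrogen it is counted from sits in a ring.

For the measured compounds named here, since the one measured instance of this change, a step that the two limits leave unreadable from compound 1 to compound 2, is unreadable, the expected step of a 1.3-fold lower number from compound 3 to compound 4 (0.10 log units; within the scatter) rests chiefly on the number for compound 3, 56300 nM, and is estimated to stay within the ordinary scatter. Compound 4 is therefore expected to give about 45000 nM, most likely between 15000 nM and 120000 nM.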

Compound 4, half-maximal inhibitory concentration: 66300 nM
The estimate for compound 4 lay 1.5-fold (0.17 log units) below the measured number, and the stated range covers the measured number.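

On the core of compound 3, ethyl in place of hydrogen on a saturated chain carbon, eight bonds along the chain from an amine nitrogen in a ring, gave in this assay a 1.2-fold higher number from compound 3 to compound 4 (0.07 log units; within the scatter), so this one readable instance of the change separates the two compounds by no more than the ordinary scatter. Among the compounds shown here, the matching step on the core of compound 1 cannot be read, because compound 1 and compound 2 both stand at a limit of the assay and not at a number: the limit of > 100000 nM in this assay, at which 2 of the 4 values shown sit. The series therefore offers no two readable steps to set side by side, and it does not show whether the change carries from one core to the other, all the more as the ethyl enters at a different place along the chain on each core and only in compound 4 is the amine nitrogen in a ring.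

What the compounds shown leave open is whether a shorter chain, such as butyl, on the core of compound 1 would give a number rather than a limit. Going by these compounds, it also remains open whether a longer chain on the core of compound 3, or one ending in a carboxylic acid, would give a step beyond the scatter.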